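A few compounds are considered here, and "the series" means these few. Any claim that something is new, unique, unknown or untested is made for them only; others in the source may bear on it.

Compounds measured so far:
- compound 1, `NC(=O)CC[C@H](NC(=O)CN(c1ncnc2c1ncn2C1CCCCO1)C1CC1)C(=O)OCc1ccccc1`, 10.7%
- compound 2, `CC(C)C[C@H](NC(=O)CN(c1ncnc2c1ncn2C1CCCCO1)C1CC1)C(=O)OCc1ccccc1`, 6.47%
- compound 3, `CC(C)C[C@H](NC(=O)CN(c1nc(Cl)nc2[nH]cnc12)C1CC1)C(=O)O`, 9.13%

The three measured compounds were all tested in a functional assay on the whole organism (Tail, strain ICR) with Mus musculus as the target, in the tail flick test, with a stated time of 150 min, at a dose of 25 umol/kg by the oral route; a higher number here means a stronger effect of the compound at the dose given, a lower number a weaker effect. In this assay compound 1 gives 10.7%, compound 2 gives 6.47% and compound 3 gives 9.13%. All three numbers lie close together, and none of the pairwise gaps is larger than the usual scatter of repeated measurements.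

Compounds 2 and 1 share a core and differ in one place: carbamoylmethyl in place of isopropyl on a saturated chain carbon, two bonds along the chain from an amide-type nitrogen and a carbonyl carbon. The step that this change made is a number 4.2 percentage points higher from compound 2 to compound 1 (within the scatter).

Compound 3 carries a different core; the difference between the core of compound 2 and the core of compound 3 is not broken down here, and the two values simply show that compound 3 and compound 2 are within the scatter of each other in this assay.

The compound still to be measured is compound 4, `NC(=O)CC[C@H](NC(=O)CN(c1nc(Cl)nc2[nH]cnc12)C1CC1)C(=O)O`. It differs from compound 3 in exactly one place: carbamoylmethyl in place of isopropyl on a saturated chain carbon, two bonds along the chain from an amide-type nitrogen and a carbonyl carbon. The place is described in the same words as for the step from compound 2 to compound 1, so this is the same change, made on the core of compound 3 rather than the core of compound 2.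

The expectation therefore rests on the one earlier occurrence of the change. The step of a number 4.2 percentage points higher from compound 2 to compound 1 (within the scatter) was within the scatter, and compound 3 itself gives 9.13%, so the step from compound 3 to compound 4 is expected to be of about the same size, a number 3.9 percentage points higher from compound 3 to compound 4 (within the scatter). With this in mind, compound 4 is estimated to give about 13% in this assay, with a likely range from 3% to 25%.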

Compound 4, a percentage reported as activity, at one dose (the size of the read-out at that dose, not a potency): 11.4%
Compound 4: the middle estimate sits 1.6 percentage points above what was measured; measured number inside the range.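

Carbamoylmethyl in place of isopropyl, on the core of compound 3, gives in this assay a number 2.3 percentage points higher from compound 3 to compound 4 (within the scatter). Set beside the earlier occurrence of this change, the new step shows no sign that the core alters what the change does, and the two occurrences can be read as one and the same small step: the same change on two cores in this assay, a number 4.2 percentage points higher (within the scatter) from compound 2 to compound 1 and a number 2.3 percentage points higher (within the scatter) from compound 3 to compound 4, 2 percentage points apart, within the scatter of two such steps

Among these compounds, this does not show that the change has a real effect on either core, since each step on its own stays within the scatter, and an agreement between two such small steps could not reveal a modest dependence on the core; it also rests on only two cores, at one dose and one time point in this assay.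

The compounds shown leave open what other groups at this place on the chain would do in this assay, such as carboxymethyl, which carries a carboxylic acid, an amine, or a longer chain ending in the same amide. They also leave open whether any group at this place can give a step that stands clear of the scatter, on either core.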